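Extending the saturated chain from compound 3 to compound 4

This account rests on a few compounds, and the source may have more. Where it says the series, first, only, none or still open, it means among the compounds named here.

Compound 1 `CCCCC(=O)Nc1ccn([C@@H]2CO[C@H](CO)O2)c(=O)n1` gives 9130 nM
Compound 2 `CCCCCCC(=O)Nc1ccn([C@@H]2CO[C@H](CO)O2)c(=O)n1` gives 2400 nM
Compound 3 `CCCCCCCCC(=O)Nc1ccn([C@@H]2CO[C@H](CO)O2)c(=O)n1` gives 276 nM

All three values come from a functional assay on SW1573 cells (Homo sapiens) for cytotoxicity, read by sulforhodamine B assay, with a stated time of 72 h (a lower number here means a stronger inhibitor, a higher number a weaker inhibitor), and, among them, compound 3 stands lowest at 276 nM on this scale. Compound 4 `CCCCCCCCCCCC(=O)Nc1ccn([C@@H]2CO[C@H](CO)O2)c(=O)n1` keeps the shared core and differs from compound 3 by propyl in place of hydrogen on a saturated chain carbon, eight bonds along the chain from a carbonyl carbon in the same chain. Two measured extensions of this chain bear most directly on the change. The first is a 3.8-fold lower number from compound 1 to compound 2 (0.58 log units; beyond the scatter) and the second is an 8.7-fold lower number from compound 2 to compound 3 (0.94 log units; beyond the scatter) in the same direction. Within the data shown here, the overall change along the series is a 33-fold lower number from compound 1 to compound 3 (1.52 log units; beyond the scatter) with no compound here going against the trend. Another step toward a lower number, of modest size, is therefore expected in this assay although no measured compound shows whether the trend holds at this chain length. The expected change is a 3.9-fold lower number from compound 3 to compound 4 (0.60 log units; beyond the scatter) on this estimate. Compound 4 is expected at about 70 nM with an estimated range from 12 nM to 350 nM in this assay.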

Compound 4, half-maximal inhibitory concentration: 30 nM
For compound 4 the middle estimate is 2.3-fold (0.37 log units) above the measured one; low and high end bracket the measured number.
By their numbers in this assay, from the lowest: compound 4; then compound 3; then compound 2; then compound 1.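

In this assay the propyl extension, on a saturated chain carbon, eight bonds along the chain from a carbonyl carbon, gives a 9.2-fold lower number from compound 3 to compound 4 (0.96 log units; beyond the scatter) and places compound 4 lowest of the four. The earlier compounds shown here stopped at a shorter chain, and this result shows that lengthening still lowers the number at this position, with no sign yet of levelling off. Across the series, the change now amounts to an 80-fold lower number from compound 2 to compound 4 (1.90 log units; beyond the scatter) and a 300-fold lower number from compound 1 to compound 4 (2.48 log units; beyond the scatter) and no compound goes against the trend.

On these data alone, whether a longer chain would lower the number further or reverse the trend remains open, as does the effect of a chain carrying an amine or a carboxylic acid. Nothing available here explains why the number falls as this chain grows.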